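Opening the sulfur ring of compound 1

The compounds below may be only part of what the source reports. "The series", "measured", "known", "first", "only" and "open" are said of these compounds alone.

In a functional assay on KB cells (Homo sapiens) for inhibition, read by MTT assay, with a stated time of 24 h, tested at 10 ug/mL (on this read-out higher numbers stand for more inhibition of growth at the one concentration tested and lower numbers for less inhibition of growth), compound 1 `O=C(CCCCC1CCSS1)Nc1cccc2ccccc12` stands as "not active" (no number reported) and so gives no single number. For the measured compounds named here, compound 3 `O=C(CCCCC(S)CCS)Nc1cccc2ccccc12` keeps the core of compound 1 and differs by a group of 5 heavy atoms (3 carbon, 2 sulfur; no ring) in place of a group of 5 heavy atoms (3 carbon, 2 sulfur; one five-membered non-aromatic ring with 2 hetero atoms), on a saturated chain carbon, four bonds along the chain from a carbonyl carbon as its only change. Going by the values given here, the one number for this open chain comes from compound 2 `O=C(CCCCC(S)CCS)Nc1ccc(Br)cn1` at 34.1% with another group on the amide. In this assay an upward step beyond the usual scatter is expected, though one compound cannot fix its size. Compound 3 is estimated at 33% with an expected range of 12% to 58% for repeat measurements.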

Compound 3, percent growth inhibition at one concentration: "not active" (no number reported)
No number was reported for compound 3; the estimate stays without a comparison.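

No step can be read between compound 1 and compound 3, as neither carries a number. No evidence on this result is available. As far as these compounds go, whether opening the ring shifts growth inhibition, and by how much, stays open.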